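The source may report more compounds than this note shows. Statements on the series, on what has been measured and on what is new or still open speak of the compounds shown alone.

Compound 1 `CN(C)C(=S)SCC(CSC(=S)N(C)C)C(=O)c1ccccc1`: 1930 nM in a functional assay on NCI-H460 cells (Homo sapiens) for inhibition, read by MTT assay, with a stated time of 72 h; on this read-out higher numbers stand for weaker inhibition and lower numbers for stronger inhibition
Compound 2 `CN(C)C(=S)SCC(CSC(=S)N(C)C)C(=O)c1ccccc1F`: 920 nM
Compound 3 `CN(C)C(=S)SCC(CSC(=S)N(C)C)C(=O)c1ccc(OCc2ccccc2)cc1`: 9770 nM

Compound 1 stands second highest of the three numbers in this assay; compound 2 is nearest to it and compound 3 furthest. Compound 4 `CN(C)C(=S)SCC(CSC(=S)N(C)C)C(=O)c1ccc(O)cc1` differs from compound 1 by hydroxy in place of hydrogen on an aromatic carbon, at a place described as para to a large group. Among the measured compounds shown here, two measured steps bear on this: a 2.1-fold lower number from compound 1 to compound 2 (0.32 log units; beyond the scatter) and a 5.1-fold higher number from compound 1 to compound 3 (0.70 log units; beyond the scatter). Both replace a ring hydrogen, one lowering the number, the other raising it. For the measured compounds named here, the hydroxy change itself has no measured counterpart, so the expected step is small, with a rise somewhat more likely than a fall. Compound 4 is thus expected to give 3000 nM in this assay, within 1000 nM to 9000 nM, an expected step of a 1.6-fold higher number from compound 1 to compound 4 (0.19 log units; within the scatter).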

Compound 4, half-maximal inhibitory concentration: 30000 nM
For compound 4 the middle estimate is 10-fold (1.00 log units) below the measured one; the measured number lies above the stated range.
By their numbers in this assay, from the lowest: compound 2; then compound 1; then compound 3; then compound 4.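

In this assay, hydroxy at this place, para to a large group, raises the number much further (a 16-fold higher number from compound 1 to compound 4 (1.19 log units; beyond the scatter)) than benzyloxy does (a 5.1-fold higher number from compound 1 to compound 3 (0.70 log units; beyond the scatter)). Taking the benzyl off the oxygen therefore does not return activity towards compound 1 but weakens it further (a 3.1-fold higher number from compound 3 to compound 4 (0.49 log units; beyond the scatter)), and compound 4 is the weakest of the four, well apart from the fluoro compound (a 33-fold higher number from compound 2 to compound 4 (1.51 log units; beyond the scatter)). No evidence at hand accounts for this rise. As far as these compounds go, whether a methoxy group, an amine or a carboxylic acid at this place would track compound 3 or compound 4 remains open.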